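The source may report more compounds than this note shows. Statements on the series, on what has been measured and on what is new or still open speak of the compounds shown alone.

Series notes. Compound 3 `CC(C)CCn1nc(C2CCCC2)c(O)c(C2=NS(=O)(=O)c3cc(NS(C)(=O)=O)ccc3N2)c1=O` is known in an ADME assay on Huh-7 cells (Homo sapiens) for cytotoxicity, with a stated time of 72 h (a higher number here means that more compound is tolerated, a lower number that less compound is tolerated), only as a limit: compound 3 gives > 1000 nM, which is a limit of the assay and not a number. The same limit of > 1000 nM in this assay, at which 2 of the 3 values shown sit, also covers compound 1 `CCCS(=O)(=O)Nc1ccc2c(c1)S(=O)(=O)N=C(c1c(O)c(-c3cccs3)nn(CCC(C)C)c1=O)N2`: in this assay compound 1 gives > 1000 nM, again a limit. Compound 2 `CC(C)CCn1nc(-c2cccs2)c(O)c(C2=NS(=O)(=O)c3cc(CS(C)(=O)=O)ccc3N2)c1=O` sits at a different limit (the limit of > 33000 nM in this assay, at which 1 of the 3 values shown sits); in this assay compound 2 gives > 33000 nM, also a limit. Among the compounds with values here, the single step between measured compounds, a step that the two limits leave unreadable from compound 1 to compound 2, runs between two limits, so its size cannot be read.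

Compound 4 `CC(C)CCc1nn(CCC(C)C)c(=O)c(C2=NS(=O)(=O)c3cc(NS(C)(=O)=O)ccc3N2)c1O` differs from compound 3 by isopentyl in place of cyclopentyl on an aromatic carbon. Within the data shown here, no measured step bears on this particular change, and the one measured step is unreadable. With compound 3 itself known only as a limit, no direction and no size beyond the scatter can be expected. For compound 4 the estimate in this assay is 10000 nM, with a range from 1000 nM to 100000 nM. The step this estimate means, a step that the limit leaves unreadable from compound 3 to compound 4, is expected to stay within the scatter, and the assay is expected most likely to report only a limit again.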

Compound 4, half-maximal cytotoxic concentration: > 33000 nM
Compound 4 gave a limit, no number; the forecaster's own chance of this, stated with the estimate: 85%; middle value at least 3.3-fold (0.51 log units) away from the limit.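

Compound 3 and compound 4 are both known only as limits in this assay, and the step between them cannot be read. The compounds shown leave open whether isopentyl in place of cyclopentyl on an aromatic carbon changes the half-maximal cytotoxic concentration at all.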